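Ortho Ethyl in Place of Bromo on the Sulfonyl Aryl

This account rests on a few compounds, and the source may have more. Where it says the series, first, only, none or still open, it means among the compounds named here.

Compound 1: `Nc1cc(S(=O)(=O)c2cccc(Cl)c2)c([N+](=O)[O-])c2cccnc12`, 892 nM
Compound 2: `Nc1cc(S(=O)(=O)c2ccccc2Br)c([N+](=O)[O-])c2cccnc12`, 234 nM

Going by the values given here, the two compounds measured so far share a core and differ only in the aryl group on the sulfonyl sulfur. In an assay for binding affinity to Neuropeptide Y receptor type 1 (Homo sapiens), read by radioligand binding (a higher number here means a weaker inhibitor, a lower number a stronger inhibitor), compound 1 gives 892 nM, while compound 2 gives 234 nM. Among the compounds with values here, the one recorded step, a 3.8-fold lower number from compound 1 to compound 2 (0.58 log units; beyond the scatter), leaves compound 2 with the lowest number of the two, the nearest being compound 1.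

Compound 3, `CCc1ccccc1S(=O)(=O)c1cc(N)c2ncccc2c1[N+](=O)[O-]`, is not yet measured. It differs from compound 2 by ethyl in place of bromo on an aromatic carbon. Within the data shown here, the only measured step moved the substituent from one position to another and changed the halogen at the same time, so it bears on the present change just indirectly: it shows that the aryl group on the sulfonyl sulfur matters in this assay, but nothing measured speaks to ethyl against bromo at the same position. Compound 3 is therefore expected to stay close to compound 2, with a step of a 1.3-fold higher number from compound 2 to compound 3 (0.11 log units; within the scatter) that need not exceed the scatter. The estimate for compound 3 in this assay is 300 nM, within 100 nM to 900 nM.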

Compound 3, inhibition constant: 129 nM
For compound 3 the middle estimate is 2.3-fold (0.37 log units) above the measured one; low and high end bracket the measured number.
By their numbers in this assay, from the lowest: compounds 3 and 2 (each within the scatter of the next); then compound 1.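

In this assay, a 1.8-fold lower number from compound 2 to compound 3 (0.26 log units; within the scatter) shows that ethyl can stand in place of bromo, ortho to a large group, without a change beyond the scatter, so a halogen is not required there for the numbers reached by compound 2. The a 6.9-fold lower number from compound 1 to compound 3 (0.84 log units; beyond the scatter) is larger than a 3.8-fold lower number from compound 1 to compound 2 (0.58 log units; beyond the scatter), and it confirms that a 2-ethylphenyl group, like 2-bromophenyl, gives a lower number than 3-chlorophenyl on the sulfonyl sulfur. No measurement available here offers a reason for either result.

As far as these compounds go, it remains open whether a longer chain such as propyl, or an amine or methoxy group, would be accepted at this place. Also open, from the compounds shown here alone, is how much of the change from 3-chlorophenyl comes from the position of the substituent and how much from its identity.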